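Hydroxyphenyl in place of nitrophenyl on the shared core

The source may report more compounds than this note shows. Statements on the series, on what has been measured and on what is new or still open speak of the compounds shown alone.

Compound 1 `COc1cc(N2C(N)=C(C#N)C(c3c(O)ccc4ccccc34)C3=C2CC(C)(C)CC3=O)cc(OC)c1OC`: 143000 nM
Compound 2 `COc1cc(N2C(N)=C(C#N)C(c3cccc([N+](=O)[O-])c3)C3=C2CC(C)(C)CC3=O)cc(OC)c1OC`: "not active" (no number reported)
Compound 3 `COc1cc(N2C(N)=C(C#N)C(c3ccccc3Cl)C3=C2CC(C)(C)CC3=O)cc(OC)c1OC`: "not active" (no number reported)

In a functional assay on Ehrlich cells (Mus musculus) for cytotoxicity (on this read-out higher numbers stand for weaker inhibition and lower numbers for stronger inhibition), compound 1 gives 143000 nM, a weak result. Compound 2 gives "not active" (no number reported), so no number places it on this scale; compound 3 likewise gives "not active" (no number reported), the only other entry without a number. Compound 4 `COc1cc(N2C(N)=C(C#N)C(c3ccccc3O)C3=C2CC(C)(C)CC3=O)cc(OC)c1OC` has not yet been measured. It differs from compound 2 by 2-hydroxyphenyl in place of 3-nitrophenyl on a saturated ring carbon. Within the data shown here, no measured pair shows what this change does on its own, and the one compound with a number, compound 1, sits far in the weak range of this assay. Compound 4 is therefore expected to stay weak in this assay, with any step from the inactive result of compound 2 at most modest, and its estimated value is 200000 nM, in a range from 60000 nM to 700000 nM.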

Compound 4, half-maximal inhibitory concentration: "not active" (no number reported)
No number was reported for compound 4; no gap can be computed for the estimate.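

In this assay compound 4, like compound 2, is reported as not active without a number, so no step can be read between them. Nothing shown here accounts for this result. The compounds shown leave open how far 2-hydroxyphenyl and 3-nitrophenyl differ on the shared core.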